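The compounds below may be only part of what the source reports. "The series", "measured", "known", "first", "only" and "open" are said of these compounds alone.

Compound 1 `O=c1[nH]c2ccccc2cc1/C=N/O` and compound 2 `Cc1ccc2[nH]c(=O)c(/C=N/O)cc2c1` share a core and differ in one place: hydrogen in place of methyl on an aromatic carbon. In a functional assay, read by spectrophotometry, with a stated time of 5 min (on this read-out higher numbers stand for weaker inhibition and lower numbers for stronger inhibition), compound 1 gives 463000 nM, and compound 2 gives 389000 nM. The step is a 1.2-fold higher number from compound 2 to compound 1 (0.08 log units; within the scatter), so the two cannot be told apart here. Compound 3 `Cc1ccc2[nH]c(=O)c(/C=N/Nc3ccc([N+](=O)[O-])cc3)cc2c1` carries a larger group in place of the small oxime of compound 2; the difference between the two cores is not broken down here. In this assay compound 3 gives "not active" (no number reported), and no number was given.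

Compound 4 `O=c1[nH]c2ccccc2cc1/C=N/Nc1ccc([N+](=O)[O-])cc1` is made from compound 3 by the same kind of change: hydrogen in place of methyl on an aromatic carbon. The surroundings of the place match the earlier change word for word. Compound 4 is expected to give about 600000 nM in this assay, with a likely range from 200000 nM to 2000000 nM, because the earlier step of a 1.2-fold higher number from compound 2 to compound 1 (0.08 log units; within the scatter) lay within the scatter and compound 3 showed no activity, so little change is expected and a second report of no activity is quite possible.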

Compound 4, half-maximal inhibitory concentration: "not active" (no number reported)
The entry for compound 4 holds no number; there is nothing to compare the estimate with.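

In this assay compound 3 and compound 4 are both reported as not active, without a number, so no step can be read between them. Nothing available here offers an explanation for this result. The compounds shown leave open whether swapping methyl for hydrogen has any effect in this pair, and how far either compound falls from compound 1 and compound 2 in numbers.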